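Swapping the Aryl Ketone Group on a Shared Core

A few compounds are considered here, and "the series" means these few. Any claim that something is new, unique, unknown or untested is made for them only; others in the source may bear on it.

Compound 1 (`COc1cc(C(=O)C2Sc3nnc(-c4cc(OC)c(OC)c(OC)c4)n3NC2c2ccco2)cc(OC)c1OC`) was examined in a functional assay on MCF7 cells (Homo sapiens) for cytotoxicity, read by MTT assay, with a stated time of 48 h; on this read-out lower numbers stand for stronger inhibition and higher numbers for weaker inhibition. In this assay compound 1 reaches only the limit > 100000 nM, which is a boundary of the measurement rather than a number. Compound 2 (`COc1cc(-c2nnc3n2NC(c2ccco2)C(C(=O)c2ccccc2F)S3)cc(OC)c1OC`) carries a 2-fluorophenyl on the carbonyl carbon, and in this assay compound 2 gives 94800 nM. The step of an at least 1.0-fold lower number from compound 1 to compound 2 (0.02 log units; that floor lies within the scatter) cannot be sized more closely because of the limit of > 100000 nM in this assay, at which 1 of the 2 values shown sits. Compound 3 (`COc1cc(-c2nnc3n2NC(c2ccco2)C(C(=O)c2ccc(Cl)cc2)S3)cc(OC)c1OC`) differs from compound 1 by 4-chlorophenyl in place of 3,4,5-trimethoxyphenyl on a carbonyl carbon. For the measured compounds named here, the only measured step that bears on this change is the one from compound 1 to compound 2, which exchanged the same 3,4,5-trimethoxyphenyl for another halogenated phenyl and left the number at the weak end of the scale. The step of an at least 1.1-fold lower number from compound 1 to compound 3 (0.04 log units; that floor lies within the scatter) is therefore expected to be small. Compound 3 is estimated at 90000 nM, within 40000 nM to 200000 nM.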

Compound 3, half-maximal inhibitory concentration: > 100000 nM
Compound 3: a limit, no number; the forecaster's own chance of this, stated with the estimate: 40%; middle value at least 1.1-fold (0.04 log units) away from the limit.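

In this assay compound 3, with 4-chlorophenyl on the carbonyl carbon, stays at a limit, so a smaller group with no hydrogen-bond acceptors in place of 3,4,5-trimethoxyphenyl gives no readable gain at this position. Exchanging 2-fluorophenyl for 4-chlorophenyl gives an at least 1.0-fold higher number from compound 2 to compound 3 (0.02 log units; that floor lies within the scatter), so the position of the halogen and its identity, which change together here, cannot be told apart by this pair. The step between compound 1 and compound 3 cannot be read because both values are limits: the limit of > 100000 nM in this assay, at which 2 of the 3 values shown sit.

On these data alone, whether any group on this carbonyl carbon can bring the number clear of the weak end of the scale remains open, for instance an amine or a carboxylic acid on the phenyl ring. As far as these compounds go, how a change elsewhere on the shared core would read also stays open.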